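Bromo for Fluoro: Expected Growth Inhibition of Compound 4

The source may report more compounds than this note shows. Statements on the series, on what has been measured and on what is new or still open speak of the compounds shown alone.

Compound 1, `O=C1NC(=S)/C(=C/c2ccc(Br)cc2)S1`, in a functional assay on NCI-H292 cells (Homo sapiens) for cytotoxicity, read by MTT assay, with a stated time of 72 h, tested at 1.25 ug/mL (on this read-out lower numbers stand for less inhibition of growth and higher numbers for more inhibition of growth at the one concentration tested), gives 1.1%.
Compound 2, `O=C1NC(=S)/C(=C/c2cccc(F)c2)S1`, in this assay gives 2.1%.
Compound 3, `O=C1NC(=S)/C(=C/c2ccc(F)cc2)S1`, in this assay gives 7.32%.

Among the measured compounds shown here, all three numbers lie within the usual scatter of one another, so no compound can be called more or less active than another. One change has been tried once already: from compound 3 to compound 1, (bromo in place of fluoro on an aromatic carbon), and it gave a number 6.2 percentage points lower from compound 3 to compound 1 (within the scatter). Compound 4, `O=C1NC(=S)/C(=C/c2cccc(Br)c2)S1`, is not yet measured; it arises from compound 2 by the same kind of change, (bromo in place of fluoro on an aromatic carbon). The surroundings differ, though: in compound 3 the group sits para to a group of 8 heavy atoms, in compound 2 meta to a group of 8 heavy atoms. How the cores of compound 2 and compound 3 differ is not broken down here. Because the earlier step of a number 6.2 percentage points lower from compound 3 to compound 1 (within the scatter) stayed within the scatter, the step from compound 2 to compound 4 is expected to be small, a number 0.6 percentage points lower from compound 2 to compound 4 (within the scatter). Compound 4 is therefore estimated at 1.5%, between -5% and 9%.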

Compound 4, percent growth inhibition at one concentration: 4.67%
Compound 4: middle estimate off by 3.2 percentage points, on the low side; the range from low to high includes it.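

In this assay, putting bromo in place of fluoro gives a number 2.6 percentage points higher from compound 2 to compound 4 (within the scatter). Set beside the earlier use of the same change, the results on the two cores cannot be told apart: the same change on two cores in this assay, a number 6.2 percentage points lower (within the scatter) from compound 3 to compound 1 and a number 2.6 percentage points higher (within the scatter) from compound 2 to compound 4, 8.8 percentage points apart, within the scatter of two such steps. This shows that the change gave only a small step on both cores, but it does not show that bromo and fluoro truly differ on either core, or that the change would push the number the same way on both.

The compounds shown carry only fluoro or bromo on the aromatic ring, leaving open whether an amine or a carboxylic acid there would give a step beyond the scatter. As far as these compounds go, a longer chain on the shared core remains equally open.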